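Phenylethynyl in Place of Phenylethenyl: Carrying a Step Across

The source may hold more compounds than are shown below. What is called first, only, known or untested is meant among the compounds shown, and "the series" means these compounds.

Measured in a functional assay on NIH3T3 cells for agonist activity at Urotensin-2 receptor (Homo sapiens), with a stated time of 5 days; on this read-out lower numbers stand for an effect already at smaller amounts and higher numbers for an effect only at larger amounts of compound:
Compound 1 `CN(C)CCC(NC(=O)/C=C/c1ccccc1)c1ccc2ccccc2c1`: 589 nM
Compound 2 `CN(C)CCC(NC(=O)C#Cc1ccccc1)c1ccc(Cl)cc1`: 398 nM
Compound 3 `CN(C)CCC(NC(=O)/C=C/c1ccccc1)c1ccc(Cl)cc1`: 427 nM

Compounds 2 and 3 share a core and differ in one place: 2-phenylethynyl in place of 2-phenylethenyl on a carbonyl carbon. The step this change made in this assay is a 1.1-fold lower number from compound 3 to compound 2 (0.03 log units; within the scatter), so the two values cannot be told apart. Compound 1 carries a different core; the difference between its core and that of compound 3 is not broken down here. Its value in this assay lies within the usual scatter of both compound 3 and compound 2, so no order among the three can be stated.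

Compound 4 `CN(C)CCC(NC(=O)C#Cc1ccccc1)c1ccc2ccccc2c1` is the not yet measured partner of compound 1. It differs from compound 1 by 2-phenylethynyl in place of 2-phenylethenyl on a carbonyl carbon. The surroundings of the place are described in the same words for both pairs, so this is the same change that turned compound 3 into compound 2. The step from compound 1 to compound 4 in this assay is expected to be about a 1.1-fold lower number from compound 1 to compound 4 (0.03 log units; within the scatter), because the earlier step of a 1.1-fold lower number from compound 3 to compound 2 (0.03 log units; within the scatter) stayed within the scatter. Compound 4 is therefore estimated at 550 nM, with a likely range from 250 nM to 1200 nM.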

Compound 4, half-maximal effective concentration: 457 nM
Estimate against measurement, compound 4: 1.2-fold (0.08 log units) above; measured number inside the range.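

In this assay, 2-phenylethynyl in place of 2-phenylethenyl on the core of compound 1 gave a 1.3-fold lower number from compound 1 to compound 4 (0.11 log units; within the scatter), so the two values cannot be told apart. The same change thus left no readable step on either core, and the two steps agree: the same change on two cores in this assay, a 1.1-fold lower number (0.03 log units; within the scatter) from compound 3 to compound 2 and a 1.3-fold lower number (0.11 log units; within the scatter) from compound 1 to compound 4, 1.2-fold (0.08 log units) apart, within the scatter of two such steps. This shows that, on these two cores, the change can be carried over without a readable step, but since both steps lie within the scatter, the agreement is between two steps too small to read, and it does not show that the change has a measurable effect of its own, that either group is preferred, or that the result would hold on any further core.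

The compounds shown leave open whether any other group on the carbonyl carbon would give a step beyond the scatter. A 2-phenylethyl group, with its saturated chain, or a longer chain ending in a carboxylic acid would be examples of such groups.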